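The source may report more compounds than this note shows. Statements on the series, on what has been measured and on what is new or still open speak of the compounds shown alone.

In a functional assay on MDA-MB-436 cells (Homo sapiens) for antiproliferative activity, read by MTT assay, with a stated time of 48 h (a lower number here means a stronger inhibitor, a higher number a weaker inhibitor), compound 1 (`C=CS(=O)(=O)N1CCN(c2ncnc3sc(-c4ccc(C#N)cc4)cc23)CC1`) gives 9170 nM, compound 2 (`C=CS(=O)(=O)N1CCN(c2nc(OC[C@H]3CCCN3C)nc3sc(-c4ccc(C#N)cc4)cc23)CC1`) gives 2290 nM and compound 3 (`C=CS(=O)(=O)N1CCN(c2nc(OC[C@H]3CCCN3C)nc3sc(-c4ccc(N5CCN(C)CC5)cc4)cc23)CC1`) gives 540 nM. Compound 2 therefore holds the middle of the three numbers, beyond the scatter from both of the others. Compound 4 (`C=CS(=O)(=O)N1CCN(c2nc(OC[C@H]3CCCN3C)nc3sccc23)CC1`) differs from compound 2 as follows: hydrogen in place of 4-cyanophenyl on an aromatic carbon.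

Among the compounds with values here, no measured step removes this group outright. The closest evidence is a 4.2-fold lower number from compound 2 to compound 3 (0.63 log units; beyond the scatter), a modest step from a change within the same group, which shows that the number responds to changes there. The similarly modest a 4.0-fold lower number from compound 1 to compound 2 (0.60 log units; beyond the scatter) concerns the (1-methylpyrrolidin-2-yl)methoxy group, which compound 4 keeps, so it bears only on the scale of change in this series. A modest step towards a higher number is expected in this assay, although the direction remains uncertain. The estimated change is a 2.6-fold higher number from compound 2 to compound 4 (0.42 log units; beyond the scatter). For compound 4 the estimated value is 6000 nM, with an expected range of 2000 nM to 18000 nM.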

Compound 4, half-maximal inhibitory concentration: > 50000 nM
Compound 4: no number, only a limit; the forecaster's own chance of this, stated with the estimate: 10%; middle value at least 8.3-fold (0.92 log units) from the limit.
By their numbers in this assay, from the lowest: compound 3; then compound 2; then compound 1. At a limit, above all of these: compound 4.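

The result for compound 4 in this assay is a limit and not a number: the limit of > 50000 nM in this assay, at which 1 of the 4 values shown sits.

Taking away the whole 4-cyanophenyl group from the aromatic carbon next to the ring sulfur gives an at least 21-fold higher number from compound 2 to compound 4 (1.33 log units; beyond the scatter), a large step. Within the data shown here, the earlier compounds showed only that the number responds to a change within this group, as in a 4.2-fold lower number from compound 2 to compound 3 (0.63 log units; beyond the scatter); compound 4 shows that, with hydrogen on this carbon, the side chain and the rest of the shared core do not hold the number at the level of compound 2.

As far as these compounds go, how far the number actually rises stays open, since the step has only a lower bound. Also open, from the compounds shown here alone, is whether a plain phenyl, a methyl or a bromine on this carbon would behave like hydrogen or like the 4-cyanophenyl group.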